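Thioether enone series: sulfur substituent swap, compound 3 to 4

The source may hold more compounds than are shown below. What is called first, only, known or untested is meant among the compounds shown, and "the series" means these compounds.

Measured compounds:
compound 1, `Cc1ccc(CS/C(=C/c2ccc(N(C)C)cc2)C(=O)c2ccc(Cl)cc2)cc1`, > 100000 nM
compound 2, `Cc1ccc(S/C(=C/c2cc(C)cc(C)c2)C(=O)c2ccc(Cl)cc2)cc1`, 50000 nM
compound 3, `CN(C)c1ccc(/C=C(/SCc2ccc(Cl)c(Cl)c2)C(=O)c2ccc(Cl)cc2)cc1`, 50000 nM

In a functional assay on DU-145 cells (Homo sapiens) for inhibition, read by trypan blue exclusion, with a stated time of 96 h (a lower number here means a stronger inhibitor of growth, a higher number a weaker inhibitor of growth), compound 3 gives 50000 nM. Compound 2, `Cc1ccc(S/C(=C/c2cc(C)cc(C)c2)C(=O)c2ccc(Cl)cc2)cc1`, gives 50000 nM in this assay, level with compound 3 at the digits shown. For compound 1, `Cc1ccc(CS/C(=C/c2ccc(N(C)C)cc2)C(=O)c2ccc(Cl)cc2)cc1`, the value in this assay is a limit, > 100000 nM, and not a number (the limit of > 100000 nM in this assay, at which 1 of the 3 values shown sits).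

Within the data shown here, the one measured step touching the sulfur substituent is an at least 2.0-fold lower number from compound 1 to compound 3 (0.30 log units; that floor lies within the scatter), and its floor lies within the scatter, so it gives no firm direction. Compound 4, `Cc1ccc(S/C(=C/c2ccc(N(C)C)cc2)C(=O)c2ccc(Cl)cc2)cc1`, is not yet measured; it differs from compound 3 by 4-methylphenyl in place of 3,4-dichlorobenzyl on a sulfur. Compound 2 carries the same 4-methylphenyl on sulfur as compound 4 and sits level with compound 3, so no step beyond the scatter is expected in this assay: a 1.2-fold higher number from compound 3 to compound 4 (0.08 log units; within the scatter). The estimate for compound 4 is 60000 nM, within 20000 nM to 200000 nM.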

Compound 4, concentration for 50% growth inhibition: > 100000 nM
Compound 4 gave a limit, no number; the forecaster's own chance of this, stated with the estimate: 35%; middle value at least 1.6-fold (0.22 log units) from the limit.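

In this assay compound 4 gives a limit, > 100000 nM, and not a number. On the sulfur, 4-methylphenyl in place of 3,4-dichlorobenzyl gives an at least 2.0-fold higher number from compound 3 to compound 4 (0.30 log units; that floor lies within the scatter), while 4-(dimethylamino)phenyl in place of 3,5-dimethylphenyl on the double-bonded chain carbon gives an at least 2.0-fold higher number from compound 2 to compound 4 (0.30 log units; that floor lies within the scatter); as printed, neither floor goes beyond the scatter, so the direction of neither change is firm. The step between the two compounds at the limit cannot be read, so the series now gives no ranking of 4-methylphenyl and 4-methylbenzyl on the sulfur: the limit of > 100000 nM in this assay, at which 2 of the 4 values shown sit.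

On these data alone, the size of both readable steps stays open while compound 4 has only a limit. Also open, as far as these compounds go, is how an amine, a carboxylic acid or a longer chain on the sulfur would read in this assay.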